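A few compounds are considered here, and "the series" means these few. Any claim that something is new, unique, unknown or untested is made for them only; others in the source may bear on it.

Compound 1 `O=C1O[C@H]([C@@H](O)Cn2cc(-c3cccc(O)c3)nn2)C(OCc2ccccc2)=C1OCc1ccccc1`: 59900 nM
Compound 2 `Cc1ccc(-c2cn(C[C@H](O)[C@H]3OC(=O)C(OCc4ccccc4)=C3OCc3ccccc3)nn2)cc1`: 8690 nM

Among the compounds with values here, in a functional assay on A549 cells (Homo sapiens) for antiproliferative activity, read by MTT assay, with a stated time of 72 h (a higher number here means a weaker inhibitor, a lower number a stronger inhibitor), compound 2 gives 8690 nM, the lower of the two numbers measured so far. Within the data shown here, the only measured step, a 6.9-fold lower number from compound 1 to compound 2 (0.84 log units; beyond the scatter), is modest but beyond the scatter; it places 4-methylphenyl where 3-hydroxyphenyl stood on an aromatic carbon.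

The next compound is compound 3 `O=C1O[C@H]([C@@H](O)Cn2cc(CCCCl)nn2)C(OCc2ccccc2)=C1OCc1ccccc1`, in which 3-chloropropyl replaces 4-methylphenyl on an aromatic carbon of a five-membered aromatic ring with 3 nitrogen: 3-chloropropyl in place of 4-methylphenyl on an aromatic carbon. That one measured step bears on this change only in part. It shows that a swap at this place can move the number in this assay, but compound 1 and compound 2 both carry a six-membered aromatic ring there, so the data say nothing directly about a group with no ring. With so little to go on, a step of similar or smaller size is expected, towards a higher number, since compound 2 holds the lower value and compound 1 stands at 59900 nM. The expected step is a 2.3-fold higher number from compound 2 to compound 3 (0.36 log units; beyond the scatter). For compound 3, the estimated value is 20000 nM, with an expected range of 6000 nM to 70000 nM.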

Compound 3, half-maximal inhibitory concentration: 29000 nM
Compound 3: the middle estimate sits 1.5-fold (0.16 log units) below what was measured; measured number inside the range.
By their numbers in this assay, from the lowest: compound 2; then compound 3; then compound 1.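

In this assay, a group with no ring can sit on this aromatic carbon of the five-membered aromatic ring with 3 nitrogen and still give a number inside the span set by the two ring-bearing compounds, with a 3.3-fold higher number from compound 2 to compound 3 (0.52 log units; beyond the scatter) and a 2.1-fold lower number from compound 1 to compound 3 (0.32 log units; beyond the scatter) as the two modest steps. A six-membered aromatic ring at this place is therefore not enough on its own to give the lower number: compound 2 carries such a ring and stands below compound 3, whereas compound 1 also carries one and stands above it. The order among these three compounds therefore depends on more than the presence or absence of a ring, and nothing available here explains these steps.

Because 3-chloropropyl differs from 4-methylphenyl in both the chlorine and the missing ring, the compounds shown cannot separate the part played by the chain from that played by the chlorine. A plain propyl chain, a longer chlorine-bearing chain, or an amine in place of the chlorine would each bear on that question, as would an unsubstituted phenyl group for the two ring-bearing compounds.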